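A few compounds are considered here, and "the series" means these few. Any claim that something is new, unique, unknown or untested is made for them only; others in the source may bear on it.

Compound 2 `O=C(CN1CCN(c2ccc(F)cc2)CC1)Nc1nc2c(s1)CCC2` gives only a limit in an assay on isolated protein for inhibition of long-chain fatty acid transport protein 1 (Mus musculus), read by scintillation counting, with a stated time of 20 min (a lower number here means a stronger inhibitor, a higher number a weaker inhibitor), namely > 10000 nM. Compound 1 `O=C(CN1CCN(c2ccncc2)CC1)Nc1nc2c(s1)CCCC2` likewise gives only a limit in this assay, namely > 10000 nM. Going by the values given here, both values sit at the limit of > 10000 nM in this assay, at which 2 of the 2 values shown sit, so no measured step between the two is available. Compound 3 `Cc1nc(NC(=O)CN2CCN(c3ccc(F)cc3)CC2)sc1C` differs from compound 2 by a group of 7 heavy atoms (5 carbon, 1 nitrogen, 1 sulfur; one five-membered aromatic ring with 2 hetero atoms) in place of a group of 8 heavy atoms (6 carbon, 1 nitrogen, 1 sulfur; one five-membered non-aromatic ring of carbon only, one five-membered aromatic ring with 2 hetero atoms), on an amide-type nitrogen. Among the compounds with values here, with no step to draw on, only a small move is expected in this assay, in no particular direction beyond the scatter. Compound 3 is therefore expected to give 15000 nM in this assay, within a range from 3000 nM to 60000 nM. The estimated step is a step that the limit leaves unreadable from compound 2 to compound 3, and a limit rather than a number is again likely.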

Compound 3, half-maximal inhibitory concentration in the long-chain fatty acid transport protein 1 assay: 1700 nM
Compound 3: the middle estimate sits 8.8-fold (0.95 log units) above what was measured; measured number outside the range, below it.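

Going by these compounds alone, in the long-chain fatty acid transport protein 1 assay the amide-type nitrogen position gives the first readable step: 4,5-dimethyl-1,3-thiazol-2-yl in place of the group on compound 2 gives an at least 5.8-fold lower number from compound 2 to compound 3 (0.76 log units; beyond the scatter). In the long-chain fatty acid transport protein 1 assay compound 3 gives 1700 nM. In the long-chain fatty acid transport protein 1 assay compound 2 gives > 10000 nM, which is a limit and not a number. This step is a lower bound, as compound 2 gives only a limit: the limit of > 10000 nM in the long-chain fatty acid transport protein 1 assay, at which 2 of the 3 values shown sit. In a physicochemical assay for lipophilicity, in phosphate buffer, measured as octanol-water partition, at pH 7.4 (on this read-out lower numbers stand for lower lipophilicity and higher numbers for higher lipophilicity), the same change gives a number 0.30 log units lower from compound 2 to compound 3 (within the scatter). In the physicochemical assay compound 2 gives 4 and compound 3 gives 3.7.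

As far as these compounds go, whether the step depends on one or both methyl groups of the 4,5-dimethyl-1,3-thiazol-2-yl group stays open. So does whether an ethyl group or a carboxylic acid in place of either methyl group would keep it.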